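The source may hold more compounds than are shown below. What is called first, only, known or untested is meant among the compounds shown, and "the series" means these compounds.

Two compounds of the series have numbers in a functional assay on Ehrlich cells (Mus musculus) for cytotoxicity, read by trypan blue exclusion, with a stated time of 2 h, tested at 100 ug/mL; a lower number here means a stronger effect, a higher number a weaker effect of the compound at the concentration tested. Compound 1 `COc1ccc2c(c1)[n+]([O-])c(C(=O)N=[N+]=[N-])c(C)[n+]2[O-]` gives 1.3% in this assay. Compound 2 `Cc1c(NC(=O)OC(C)C)[n+]([O-])c2cc(Cl)ccc2[n+]1[O-]` gives 90.6% in this assay, the highest of the two numbers; the nearest, compound 1, lies lower by a gap beyond the usual scatter. Within the data shown here, compounds 1 and 2 differ in more than one place, so no single step between them is counted, and their two values show only that compound 2 has the weaker effect at the concentration tested.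

Compound 3 `COc1ccc2c(c1)[n+]([O-])c(NC(=O)OC(C)C)c(C)[n+]2[O-]` is the next compound to be measured in this assay. It differs from compound 2 in one place: methoxy in place of chloro on an aromatic carbon. Among the measured compounds shown here, no measured pair isolates this exchange, so its size is not known from the data. Because compound 2 gives 90.6% in this assay and only one substituent is exchanged, the expected step is a number 8.6 percentage points lower from compound 2 to compound 3 (within the scatter), small and with no direction beyond the scatter. Compound 3 is estimated to give 82% in this assay, within a range of 55% to 98%.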

Compound 3, a percentage reported as activity, at one concentration (the size of the read-out at that concentration, not a potency): 63.2%
The estimate for compound 3 lay 18.8 percentage points above the measured number; low and high end bracket the measured number.
By their numbers in this assay, from the lowest: compound 1; then compound 3; then compound 2.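

In this assay, among these compounds, the ring carbon that carries chloro in compound 2 proves not to be a silent position: a number 27.4 percentage points lower from compound 2 to compound 3 (beyond the scatter), so methoxy in place of chloro gives the stronger effect at the concentration tested, and this pair is the first to isolate that exchange. The other substituted aromatic carbon carries a much bigger difference, a number 61.9 percentage points higher from compound 1 to compound 3 (beyond the scatter), so with methoxy held constant, the group of 7 heavy atoms gives a far weaker effect than the group of 5 heavy atoms, a large step against the modest one at the chloro position. No measurement available here accounts for either step.

From the compounds shown here alone, the methoxy-for-chloro step rests on a single pair, so it remains open whether it keeps its size and direction when the group of 5 heavy atoms occupies the other aromatic carbon. Also open, going by these compounds, is how the read-out responds at the same ring carbon to hydrogen, fluoro, an amine or a longer chain such as ethoxy, and whether the read-out follows any order across such groups.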